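The source may hold more compounds than are shown below. What is called first, only, known or untested is meant among the compounds shown, and "the series" means these compounds.

Measured in a functional assay on MCF7 cells (Homo sapiens) for cytotoxicity, with a stated time of 72 h; a higher number here means a weaker inhibitor, a lower number a stronger inhibitor:
compound 1 `Cc1cccc(-c2nn3c(c2-c2ccnc(Nc4ccc(S(N)(=O)=O)cc4)c2)C(C)C(C)(C)C3)n1`: 22000 nM
compound 2 `CCc1cccc(-c2nn3c(c2-c2ccncc2)C(C)C(C)(C)C3)n1`: > 100000 nM (a limit)

In this assay compound 2 gives > 100000 nM, which is a limit of the assay and not a number. Compound 3 `CCc1cccc(-c2nn3c(c2-c2ccnc(Nc4ccc(S(N)(=O)=O)cc4)c2)C(C)C(C)(C)C3)n1` follows from compound 2 through ((4-sulfamoylphenyl)amino in place of hydrogen on an aromatic carbon). Compound 1 also carries (4-sulfamoylphenyl)amino and reads 22000 nM, so a clear step towards stronger inhibition in this assay is expected, beyond the scatter. The estimated size of that step is an at least 5.0-fold lower number from compound 2 to compound 3 (0.69 log units; beyond the scatter). The expected value for compound 3 is 20000 nM, with an estimated range of 7000 nM to 60000 nM.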

Compound 3, half-maximal inhibitory concentration: 28000 nM
Estimate against measurement, compound 3: 1.4-fold (0.15 log units) below, and the stated range covers the measured number.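

In this assay, the change at the aromatic carbon next to the ring nitrogen can now be read on its own: (4-sulfamoylphenyl)amino in place of hydrogen gives an at least 3.5-fold lower number from compound 2 to compound 3 (0.55 log units; beyond the scatter). The true size of that step stays unknown because compound 2 is a limit of the assay and not a number: the limit of > 100000 nM in this assay, at which 1 of the 3 values shown sits.

With (4-sulfamoylphenyl)amino present, methyl in place of hydrogen on the chain carbon gives a 1.3-fold higher number from compound 1 to compound 3 (0.10 log units; within the scatter), so the methyl and ethyl compounds read alike.

Still open, going by these compounds, is whether the sulfamoyl group or the amino-linked phenyl ring accounts for the step; a plain phenylamino group or a carboxylic acid in place of the sulfamoyl group would separate the two. On these data alone, a propyl chain in place of ethyl also remains open.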